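Series notes: half-life step from compound 3 to compound 4

The source may report more compounds than this note shows. Statements on the series, on what has been measured and on what is new or still open speak of the compounds shown alone.

Three members of the series have been run in an in vivo ADME assay on the whole organism for metabolic stability, with Homo sapiens as the target, read by LC-MS, at a dose of 320 mg/kg by the oral route; on this read-out lower numbers stand for a shorter-lived compound and higher numbers for a longer-lived compound. Compound 1 `CC(C)N/C(=N\C(=O)C(C)(C)C)NC1=NC(=O)CN1c1ccc(Cl)c(Cl)c1` gives 0.674 h. Compound 3 `CC(C)/N=C(\NC1=NC(=O)CN1C(C)C)Nc1ccc(Cl)c(Cl)c1` gives 0.883 h, the higher of the two plain numbers shown, but its gap to compound 1 lies within the usual scatter, so the two cannot be ordered against each other. For compound 2 `CC(C)(C)N/C(=N/C1=NC(=O)CN1c1ccc(Cl)c(Cl)c1)Nc1ccc(Cl)c(Cl)c1` this assay reports > 1 h, which is the limit of > 1 h in this assay, at which 1 of the 3 values shown sits, and not a number. Within the data shown here, no pair of measured compounds differs in only one place, so no measured step exists to guide the next one.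

Compound 4 `CCOC(=O)/N=C(\NC1=NC(=O)CN1C(C)C)Nc1ccc(Cl)c(Cl)c1` has not yet been measured in this assay. It is derived from compound 3 by one change: ethoxycarbonyl in place of isopropyl on a double-bonded nitrogen. Among the measured compounds shown here, with compound 3 as the only anchor and no measured step of comparable kind, the expectation is that the step of a 1.1-fold lower number from compound 3 to compound 4 (0.04 log units; within the scatter) stays within the scatter of repeated measurements, without a clear direction. Compound 4 is therefore estimated at 0.8 h in this assay, with a range from 0.4 h to 1.6 h, and a real chance that the assay again returns only a limit, as it did for compound 2.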

Compound 4, half-life: 0.572 h
Beside the measured number, compound 4's estimate is 1.4-fold (0.15 log units) above it, within the range that was stated.
By their numbers in this assay, from the lowest: compounds 4, 1 and 3 (each within the scatter of the next). At a limit, above all of these: compound 2.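

Ethoxycarbonyl in place of isopropyl on a double-bonded nitrogen is the first measured step in the series, and in this assay it gives a 1.5-fold lower number from compound 3 to compound 4 (0.19 log units; within the scatter). The position therefore takes a group with 5 heavy atoms, 2 hydrogen-bond acceptors and a double bond in place of one with 3 heavy atoms and no hydrogen-bond acceptors, with no half-life difference that can be told from repeat scatter. Nothing shown gives a reason for this outcome, and a single step within the scatter does not set a direction for the change.

A single step leaves open how half-life responds to other groups on this double-bonded nitrogen, such as a carboxylic acid, a primary amine or a longer chain like butoxycarbonyl, any of which would show whether the flat result extends past this one pair. It also leaves open whether the same exchange behaves alike on a compound with a different group elsewhere on the shared core, since this pair is the only one shown that differs in one place.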